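The source may hold more compounds than are shown below. What is called first, only, known or untested is meant among the compounds shown, and "the series" means these compounds.

Working notes on the series. Compound 1 `Oc1cccc(-c2cc(-c3ccncc3)nc(-c3cccc(Cl)c3)c2)c1` gives 0% in an assay on isolated protein for inhibition of DNA topoisomerase 1 (Homo sapiens), with a stated time of 30 min, tested at 100 uM; a higher number here means a stronger effect of the compound at the concentration tested, a lower number a weaker effect. Compound 2 `Oc1cccc(-c2cc(-c3cccc(Cl)c3)nc(-c3ccco3)c2)c1` gives 5.5% in this assay, and compound 3 `Oc1cccc(-c2cc(-c3ccc(Cl)cc3)nc(-c3ccco3)c2)c1` gives 27.1%, the highest of the three, with compound 2 nearest and compound 1 furthest. Compound 2 and compound 3 have the same atoms joined differently, (4-chlorophenyl in place of 3-chlorophenyl on an aromatic carbon), and the step is a number 21.6 percentage points higher from compound 2 to compound 3 (beyond the scatter). The change pyridin-4-yl in place of furan-2-yl on an aromatic carbon made the step of a number 5.5 percentage points lower from compound 2 to compound 1 (within the scatter). Compound 4 `Oc1cccc(-c2cc(-c3ccncc3)nc(-c3ccc(Cl)cc3)c2)c1` is not yet measured and differs from compound 3 by the same kind of change, (pyridin-4-yl in place of furan-2-yl on an aromatic carbon), the place here being meta to a 4-chlorophenyl group rather than meta to a 3-chlorophenyl group. Because the earlier step of a number 5.5 percentage points lower from compound 2 to compound 1 (within the scatter) lay within the scatter, a step of similar size is expected now, a number 6.1 percentage points lower from compound 3 to compound 4 (within the scatter). Compound 4 is estimated at 21%, between 6% and 38%.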

Compound 4, a percentage reported as inhibition, at one concentration (the size of the read-out at that concentration, not a potency): 8%
For compound 4 the middle estimate is 13 percentage points above the measured one, and the stated range covers the measured number.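

In this assay, the pyridin-4-yl change gives a number 19.1 percentage points lower from compound 3 to compound 4 (beyond the scatter), and this step cannot be told apart from the earlier one: the same change on two cores in this assay, a number 5.5 percentage points lower (within the scatter) from compound 2 to compound 1 and a number 19.1 percentage points lower (beyond the scatter) from compound 3 to compound 4, 13.6 percentage points apart, within the scatter of two such steps. The 4-chlorophenyl change gives a number 8 percentage points higher from compound 1 to compound 4 (within the scatter), and it too carries across the two cores without a separable difference: the same change on two cores in this assay, a number 21.6 percentage points higher (beyond the scatter) from compound 2 to compound 3 and a number 8 percentage points higher (within the scatter) from compound 1 to compound 4, 13.6 percentage points apart, within the scatter of two such steps. Going by these compounds alone, these two pairs, each read at a single concentration, do not show that either change keeps a fixed size on other cores; they show only that the steps within each pair do not separate.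

The compounds shown leave open whether an amine or a carboxylic acid in place of furan-2-yl would alter the inhibition. They also leave open the effect of a methoxy group in place of the hydroxyl of the 3-hydroxyphenyl group.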